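Working notes on a small acyl sulfonamide anilide series

The compounds below may be only part of what the source reports. "The series", "measured", "known", "first", "only" and "open" are said of these compounds alone.

Of the compounds shown here, three have been measured. Compound 1 `CCC(C)C(C(=O)Nc1ccc(C(C)=O)cc1)N(C(=O)c1ccccc1)S(=O)(=O)c1ccc(C)cc1` gives 10000000 nM in a functional assay, read by spectrophotometry, with a stated time of 20 min; a lower number here means a stronger inhibitor, a higher number a weaker inhibitor. Compound 2 `CC(=O)c1ccc(NC(=O)C(C(C)C)N(C(=O)c2ccccc2)S(=O)(=O)c2ccc(C)cc2)cc1` gives 12000000 nM in this assay. Compound 3 `CCC(C)C(C(=O)Nc1ccc(C(C)=O)cc1)N(C(=O)c1ccccc1)S(=O)(=O)c1ccccc1` gives 8600000 nM in this assay. The numbers sit close together: a 1.2-fold higher number from compound 1 to compound 2 (0.08 log units; within the scatter), and a 1.2-fold lower number from compound 1 to compound 3 (0.07 log units; within the scatter). Compound 3 carries the lowest number of the three, but its gaps to compound 1 and compound 2 are within the scatter, so no order among them can be read from these data.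

Compound 4 `CC(=O)c1ccc(NC(=O)C(C(C)C)N(C(=O)c2ccccc2)S(=O)(=O)c2ccccc2)cc1` has not yet been measured. It differs from compound 3 by hydrogen in place of methyl on a saturated chain carbon, three bonds along the chain from an amide-type nitrogen and a carbonyl carbon. The same change has been made once before, from compound 1 to compound 2, where it reads hydrogen in place of methyl on a saturated chain carbon, three bonds along the chain from an amide-type nitrogen and a carbonyl carbon and gave a 1.2-fold higher number from compound 1 to compound 2 (0.08 log units; within the scatter). The two place descriptions agree word for word, so this is the same change, made on a second core. The two cores differ by hydrogen in place of methyl on an aromatic carbon, which between compound 1 and compound 3 gave a 1.2-fold lower number from compound 1 to compound 3 (0.07 log units; within the scatter).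

Within the data shown here, with only a single earlier instance to go on, the expected step is a 1.2-fold higher number from compound 3 to compound 4 (0.07 log units; within the scatter) because the one previous instance of this change gave a 1.2-fold higher number from compound 1 to compound 2 (0.08 log units; within the scatter). For compound 4 the estimate in this assay is 10000000 nM, with a plausible range from 5000000 nM to 20000000 nM.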

Compound 4, half-maximal inhibitory concentration: 13000000 nM
Compound 4: the middle estimate sits 1.3-fold (0.11 log units) below what was measured, and the stated range covers the measured number.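

In this assay, the exchange of sec-butyl for isopropyl gives a 1.5-fold higher number from compound 3 to compound 4 (0.18 log units; within the scatter), and this step reads the same as the one made on the core of compound 1: the same change on two cores in this assay, a 1.2-fold higher number (0.08 log units; within the scatter) from compound 1 to compound 2 and a 1.5-fold higher number (0.18 log units; within the scatter) from compound 3 to compound 4, 1.3-fold (0.10 log units) apart, within the scatter of two such steps. The loss of the methyl on the aromatic carbon, taken on the isopropyl core, gives a 1.1-fold higher number from compound 2 to compound 4 (0.03 log units; within the scatter), and this step likewise agrees with the one on the sec-butyl core: the same change on two cores in this assay, a 1.2-fold lower number (0.07 log units; within the scatter) from compound 1 to compound 3 and a 1.1-fold higher number (0.03 log units; within the scatter) from compound 2 to compound 4, 1.3-fold (0.10 log units) apart, within the scatter of two such steps. Both changes therefore carry from one core to the other with no difference that these data can detect, but every step lies within the scatter, so neither change is shown to have any effect of its own, and agreement between steps this small says little about whether a larger effect would also carry across cores.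

The four compounds vary only in sec-butyl against isopropyl and in the presence or absence of the aromatic methyl, so they leave open whether any change in this series can give a number beyond the scatter of these four. Whether a longer chain or an amine in place of the sec-butyl, or a carboxylic acid in place of the aromatic methyl, would do so cannot be told from these data.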